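The source may hold more compounds than are shown below. What is called first, only, known or untested is meant among the compounds shown, and "the series" means these compounds.

Working notes on the series. Of the compounds shown here, three sharing one core have been measured, differing in the side arm attached to the amide-type nitrogen. Compound 1 `CC(C)(C)OC(=O)NC1CCN(C(=O)CN2CN(c3ccccc3)C3(CCN(C(=O)c4ccc(C(C)(C)C)cc4)CC3)C2=O)CC1` gives 8300 nM in an assay on HEK293 cells for displacement of a labelled ligand from NPC1-like intracellular cholesterol transporter 1 (Homo sapiens); on this read-out higher numbers stand for weaker inhibition and lower numbers for stronger inhibition. Within the data shown here, compound 3 `CC(C)(C)OC(=O)NCC1CCN(C(=O)CN2CN(c3ccccc3)C3(CCN(C(=O)c4ccc(C(C)(C)C)cc4)CC3)C2=O)CC1` gives 4200 nM in this assay; the one measured step, a 2.0-fold lower number from compound 1 to compound 3 (0.30 log units; within the scatter), does not leave the scatter. Compound 2 `CC(C)(C)OC(=O)NCCCCCNC(=O)CN1CN(c2ccccc2)C2(CCN(C(=O)c3ccc(C(C)(C)C)cc3)CC2)C1=O` gives 13700 nM in this assay, the highest of the three numbers: compound 1 is the nearest, and those two values lie within the scatter of each other, while compound 3 is the furthest, beyond the scatter.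

Compound 4 `CC(C)(C)c1ccc(C(=O)N2CCC3(CC2)C(=O)N(CC(=O)NCCCCCO)CN3c2ccccc2)cc1` is not yet measured. It differs from compound 2 in one place: hydroxy in place of (tert-butoxycarbonyl)amino on a saturated chain carbon, five bonds along the chain from an amide-type nitrogen. Among the measured compounds shown here, no measured step covers this change. The single step shown, a 2.0-fold lower number from compound 1 to compound 3 (0.30 log units; within the scatter), concerns a different change, and that step stays within the scatter; it says nothing about removal of the (tert-butoxycarbonyl)amino group in favour of hydroxy. Lacking any comparable step, the expected change a 1.1-fold higher number from compound 2 to compound 4 (0.04 log units; within the scatter) is set to none beyond the scatter, with a wide range to reflect the absence of support. Compound 4 is expected to give 15000 nM in this assay, in the range 5000 nM to 50000 nM.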

Compound 4, half-maximal inhibitory concentration: 9400 nM
The estimate for compound 4 lay 1.6-fold (0.20 log units) above the measured number, and the stated range covers the measured number.
By their numbers in this assay, from the lowest: compounds 3, 1, 4 and 2 (each within the scatter of the next, the first and the last beyond it).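

In this assay, hydroxy in place of (tert-butoxycarbonyl)amino on a saturated chain carbon, five bonds along the chain from an amide-type nitrogen, gives a 1.5-fold lower number from compound 2 to compound 4 (0.16 log units; within the scatter). Compounds 1, 2 and 3 all carry the (tert-butoxycarbonyl)amino group, so they could not show what happens when it leaves; here a group of 8 heavy atoms gives way to one of 1 heavy atom, and the number stays within the scatter, so at this place on the chain the read-out does not depend measurably on the full group. Nothing available explains this result, and no measurement bears on it beyond the number itself.

Still open, as far as these compounds go, is whether an amine, a carboxylic acid or a methyl ether in place of the hydroxy at this position would stay within the scatter of compound 4, and whether a longer or shorter chain carrying the same hydroxy would do so. Also open, from the compounds shown here alone, is whether hydroxy in place of (tert-butoxycarbonyl)amino on the saturated ring carbon of compound 1 would give a similarly small step.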